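Removing one methoxy group from the aryl ring of compound 1

The source may hold more compounds than are shown below. What is called first, only, known or untested is meant among the compounds shown, and "the series" means these compounds.

Measured compounds:
compound 1, `COc1cc(-c2cc(/C=C/C(=O)c3ccc(N)cc3)[nH]n2)cc(OC)c1OC`, -98%;
compound 2, `COc1ccc(-c2cc(/C=C/C(=O)c3ccc(OC)c(OC)c3)[nH]n2)cc1`, -100%;
compound 3, `COc1cc(-c2cc(/C=C/C(=O)c3ccc(Cl)c(Cl)c3)[nH]n2)cc(OC)c1OC`, -5%.

Three compounds sharing one core have been run in a functional assay on U-251 cells (Homo sapiens) for cytotoxicity, read by sulforhodamine B assay, with a stated time of 48 h, tested at 100 uM; on this read-out lower numbers stand for a stronger effect and higher numbers for a weaker effect at the one concentration tested. Compound 1 stands second highest of the three numbers there; its nearest neighbour is compound 2, whose value lies within the scatter of that of compound 1, while compound 3 lies far above it. For the measured compounds named here, the one step between compounds that differ in a single place is a number 93 percentage points higher from compound 1 to compound 3 (beyond the scatter), and it concerns the aryl group on the carbonyl carbon, not the ring carrying the methoxy groups.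

Compound 4, `COc1ccc(-c2cc(/C=C/C(=O)c3ccc(N)cc3)[nH]n2)cc1OC`, has not yet been measured in this assay. It differs from compound 1 in this way: hydrogen in place of methoxy on an aromatic carbon.

Going by the values given here, no measured step alters this ring alone, so nothing bears directly on the change. Compound 2, which carries a single methoxy group on the corresponding ring, gives -100%, a value within the scatter of compound 1, so compound 4 is expected to show a number 6 percentage points higher from compound 1 to compound 4 (within the scatter), no step beyond the scatter. Compound 4 is therefore estimated at -92%, within -100% to -65%.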

Compound 4, a percentage reported as activity, at one concentration (the size of the read-out at that concentration, not a potency): -96%
Compound 4: middle estimate off by 4 percentage points, on the high side; low and high end bracket the measured number.
By their numbers in this assay, from the lowest: compounds 2, 1 and 4 (each within the scatter of the next); then compound 3.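

In this assay, hydrogen in place of the methoxy group gives a number 2 percentage points higher from compound 1 to compound 4 (within the scatter), the first step shown that alters only this ring. With the 4-aminophenyl group kept on the carbonyl carbon, this methoxy group, ortho to a methoxy group and meta to a large group, can therefore be replaced by hydrogen without a change beyond the scatter at the one concentration tested. Nothing on hand accounts for this result.

As far as these compounds go, whether the same change would also stay within the scatter with the 3,4-dichlorophenyl group of compound 3 on the carbonyl carbon remains open. So does the outcome of placing a hydroxy group or a fluorine atom on this aromatic carbon instead of hydrogen.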